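Tert-Butyl in Place of Methoxy on the Benzyl Arm

This account rests on a few compounds, and the source may have more. Where it says the series, first, only, none or still open, it means among the compounds named here.

Compound 1, `O=C(NO)c1ccc(CN2C(=O)NC(Cc3ccccc3)(c3ccccc3)C2=O)cc1`, in an assay on isolated protein for inhibition of protein deacetylase HDAC6 (Homo sapiens), read by fluorescence, with stated times of 10 min and 2 h (on this read-out higher numbers stand for weaker inhibition and lower numbers for stronger inhibition), gives 71.9 nM.
Compound 2, `COc1ccc(CC2(c3ccccc3)NC(=O)N(Cc3ccc(C(=O)NO)cc3)C2=O)cc1`, in this assay gives 72.4 nM.

Compound 2 stands level with compound 1 on the two numbers available: a 1.0-fold higher number from compound 1 to compound 2 (0.00 log units; within the scatter). The step to compound 3, `CC(C)(C)c1ccc(CC2(c3ccccc3)NC(=O)N(Cc3ccc(C(=O)NO)cc3)C2=O)cc1`, is tert-butyl in place of methoxy on an aromatic carbon. Going by the values given here, the only measured step that bears on this position is the one from compound 1 to compound 2, where placing methoxy on this aromatic carbon left the number unchanged within the scatter. Among the compounds with values here, no measured compound carries tert-butyl, so the data give no footing for a shift in either direction, and a step of no more than the scatter is expected in this assay. Compound 3 is therefore estimated at 80 nM, with a range from 35 nM to 200 nM. The expected step for compound 3 is a 1.1-fold higher number from compound 2 to compound 3 (0.04 log units; within the scatter).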

Compound 3, half-maximal inhibitory concentration: 115 nM
Beside the measured number, compound 3's estimate is 1.4-fold (0.16 log units) below it; low and high end bracket the measured number.
By their numbers in this assay, from the lowest: compounds 1, 2 and 3 (each within the scatter of the next).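

In this assay, the change from 4-methoxybenzyl to 4-(tert-butyl)benzyl gives a 1.6-fold higher number from compound 2 to compound 3 (0.20 log units; within the scatter) and the change from the unsubstituted ring to tert-butyl gives a 1.6-fold higher number from compound 1 to compound 3 (0.20 log units; within the scatter) so this aromatic carbon, para to a large group, has now taken a group of four heavy atoms without any step leaving the scatter. Together with the earlier methoxy step, this means hydrogen, methoxy and tert-butyl all stand within the scatter of one another here, which the first two compounds alone could not show for a group of this size. No evidence on the cause of this result is available.

Still open, from the compounds shown here alone, is whether an amine, a carboxylic acid or a longer chain on this carbon would give a step beyond the scatter. The compounds shown also leave open whether the same tolerance holds for tert-butyl elsewhere on this ring.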